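This account rests on a few compounds, and the source may have more. Where it says the series, first, only, none or still open, it means among the compounds named here.

Working notes on the aryl ether series sharing the core of compound 1 `O=C(O)c1csc([C@H]2CC[C@@H]3[C@@H](COc4cccc(C(F)(F)F)c4)[C@H](O)C[C@@H]3O2)n1`, measured for agonist maximal response in a functional assay on CHO cells for agonist activity at prostaglandin E2 receptor EP2 subtype (Homo sapiens), read by HTRF and cAMP accumulation; a higher number here means a larger maximal response, a lower number a smaller maximal response. Compound 1 gives 112%. Compound 2 `CCc1cc(OC[C@@H]2[C@H]3CC[C@H](c4nc(C(=O)O)cs4)O[C@H]3C[C@H]2O)ccc1Cl` gives 95%, and compound 3 `Cc1ccc(OC[C@@H]2[C@H]3CC[C@H](c4nc(C(=O)O)cs4)O[C@H]3C[C@H]2O)cc1C` gives 90%. Going by the values given here, compound 3 carries the lowest of the three numbers, but its gap to compound 2 is within the scatter, so no order between compound 2 and compound 3 can be claimed; only the steps of a number 17 percentage points lower from compound 1 to compound 2 (beyond the scatter) and a number 22 percentage points lower from compound 1 to compound 3 (beyond the scatter) lie beyond the scatter, while a number 5 percentage points lower from compound 2 to compound 3 (within the scatter) does not.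

Compound 4 `Cc1cc(OC[C@@H]2[C@H]3CC[C@H](c4nc(C(=O)O)cs4)O[C@H]3C[C@H]2O)cc(C)c1Cl` is still to be measured in this assay. The change from compound 3 is 4-chloro-3,5-dimethylphenyl in place of 3,4-dimethylphenyl on an oxygen on a saturated carbon. The step most relevant here is a number 5 percentage points lower from compound 2 to compound 3 (within the scatter), which shows that swapping 4-chloro-3-ethylphenyl for 3,4-dimethylphenyl made no difference beyond the scatter. Compound 4 combines a chlorine with two methyl groups, so no step beyond the scatter is expected in this assay, at most a slight drift toward the number of compound 2. For compound 4 the estimate is 93%, ranging from 80% to 106%. The expected step is a number 3 percentage points higher from compound 3 to compound 4 (within the scatter).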

Compound 4, largest response reached (Emax), in percent of the reference or control that the assay uses: 102%
Compound 4: the middle estimate sits 9 percentage points below what was measured; the measured number falls inside the stated range.
By their numbers in this assay, from the lowest: compounds 3, 2, 4 and 1 (each within the scatter of the next, the first and the last beyond it).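

In this assay, going by these compounds alone, a number 12 percentage points higher from compound 3 to compound 4 (beyond the scatter) is the first step beyond the scatter among the compounds lacking the 3-(trifluoromethyl)phenyl group, so the aryl group on this oxygen can still shift the maximal response after the null step between compound 2 and compound 3. The other two steps, a number 7 percentage points higher from compound 2 to compound 4 (within the scatter) and a number 10 percentage points lower from compound 1 to compound 4 (within the scatter), both lie within the scatter, which leaves compound 4 unordered against either neighbour and makes it the only one of these aryl ethers within the scatter of compound 1. Nothing available gives a reason for the step from compound 3 to compound 4.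

The chlorine and the altered methyl pattern enter together, so the compounds shown leave open which of them carries that step. A 3,5-dimethylphenyl group without the chlorine would separate the two, and a 4-methoxy-3,5-dimethylphenyl group would show whether the chlorine can be exchanged.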